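Naphthoquinone esters and an ether: HeLa cytotoxicity notes

This account rests on a few compounds, and the source may have more. Where it says the series, first, only, none or still open, it means among the compounds named here.

Measured so far:
compound 1, `CC(=O)Oc1ccc2c(c1)C(=O)C=CC2=O`, 27700 nM
compound 2, `CS(=O)(=O)OC1=CC(=O)c2ccccc2C1=O`, 7610 nM

Two compounds of the shared core have numbers in a functional assay on HeLa cells (Homo sapiens) for cytotoxicity; on this read-out lower numbers stand for stronger inhibition and higher numbers for weaker inhibition. Compound 1 carries an acetyl ester on the aromatic ring and gives 27700 nM. Compound 2 carries a (methylsulfonyl)oxy group on the quinone ring and gives 7610 nM. Compound 2 thus stands lowest of the two, and its gap to compound 1 lies beyond the scatter of this assay, so compound 2 reads as the stronger inhibitor of the pair.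

Compound 3, `CCCCOC1=CC(=O)c2ccccc2C1=O`, is not yet measured. It differs from compound 2 in one place: butyl in place of methylsulfonyl on an oxygen on an unsaturated carbon. The methylsulfonyl group, with its two hydrogen-bond acceptors and its sulfur, leaves; a butyl chain of four carbons enters on the same oxygen, so (methylsulfonyl)oxy becomes butoxy.

Within the data shown here, no step between measured compounds with a comparable change is available, so the expectation rests on compound 2 alone. A small weakening is expected, near the edge of the scatter, with the step from compound 2 to compound 3 estimated at a 1.6-fold higher number from compound 2 to compound 3 (0.20 log units; within the scatter). Compound 3 is therefore expected to give about 12000 nM, with a range from 3500 nM to 40000 nM.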

Compound 3, half-maximal inhibitory concentration: 35300 nM
Beside the measured number, compound 3's estimate is 2.9-fold (0.47 log units) below it, and the stated range covers the measured number.
By their numbers in this assay, from the lowest: compound 2; then compounds 1 and 3 (each within the scatter of the next).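

In this assay, among these compounds, this is the first single change that can be read on its own: butyl in place of methylsulfonyl on an oxygen on an unsaturated carbon gives (a 4.6-fold higher number from compound 2 to compound 3 (0.67 log units; beyond the scatter)), a step beyond the scatter and toward weaker inhibition. The group on this oxygen therefore moves the read-out, which the earlier pair of compounds, differing in more than one place, could not show. No measurement on these compounds bears on why the number moves, so the step stands as an observation only.

With a single pair at this oxygen, the compounds shown cannot separate the loss of methylsulfonyl from the entry of butyl, nor show whether the step belongs to sulfonate against ether or to this particular chain. A shorter chain such as ethyl or a longer chain such as octyl on the same oxygen, or an amine in place of that oxygen, would show how far the change in the number follows the group that enters.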